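A Drawn Stereocentre on a Chloro-Substituted Chain Compound

The source may report more compounds than this note shows. Statements on the series, on what has been measured and on what is new or still open speak of the compounds shown alone.

Among the compounds with values here, in a functional assay on HCT-116 cells (Homo sapiens) for antiproliferative activity, read by MTT assay, with a stated time of 48 h (on this read-out higher numbers stand for weaker inhibition and lower numbers for stronger inhibition), compound 2 `CCCCCCCCCC(CCCl)n1cnc2c(Cl)ncnc21` gives 10200 nM, the higher of the two numbers measured so far. Compound 1 `CCCCCCCCC[C@H](CCN=[N+]=[N-])n1cnc2c(Cl)ncnc21` gives 1190 nM, and this gap lies beyond the scatter of repeated measurements. Compound 3 `CCCCCCCCC[C@H](CCCl)n1cnc2c(Cl)ncnc21` has not yet been measured. It keeps every atom and bond of compound 2, and the only difference is one of drawing: the two compounds have the same atoms and bonds; at least one stereo element is drawn with a configuration in one of them and without one in the other: 1 of 1 stereo elements differ; a stereocentre at a saturated chain carbon is drawn without a configuration in compound 2 and R in compound 3. Within the data shown here, no measured pair shows the size of such a change in this assay, so the expectation rests on the value of compound 2 alone. No step beyond the scatter is expected, and the data favour neither direction. The expected step of a 1.1-fold lower number from compound 2 to compound 3 (0.05 log units; within the scatter) therefore stays small. For compound 3 the estimated value is 9000 nM, with an expected range from 4000 nM to 20000 nM.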

Compound 3, half-maximal inhibitory concentration: 9580 nM
For compound 3 the middle estimate is 1.1-fold (0.03 log units) below the measured one; the measured number falls inside the stated range.
By their numbers in this assay, from the lowest: compound 1; then compounds 3 and 2 (each within the scatter of the next).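

In this assay drawing the saturated chain carbon as R, in place of no configuration, brings no step beyond the scatter (a 1.1-fold lower number from compound 2 to compound 3 (0.03 log units; within the scatter)). The pair therefore speaks only to a defined against an undefined centre, and its one difference is a matter of drawing: the fact that one of compounds 2 and 3 is drawn with a defined configuration and the other without, at the place where they differ. Compound 3 also allows a comparison with compound 1 that differs in one place, and chloro in place of azido on a saturated chain carbon, three bonds along the chain from an aromatic nitrogen, goes with weaker inhibition beyond the scatter (an 8.1-fold higher number from compound 1 to compound 3 (0.91 log units; beyond the scatter)).

The compounds shown leave open how the S configuration at this chain carbon would compare. They also leave open how an amine or a carboxylic acid in place of chloro or azido would stand in this assay.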